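Replacing a propyl by a phenyl on the sulfonamide nitrogen

This account rests on a few compounds, and the source may have more. Where it says the series, first, only, none or still open, it means among the compounds named here.

Compound 1 `CCCNS(=O)(=O)c1ccc(Nc2ncc3c(n2)N(C2CCCC2)[C@H](CC)C(=O)N3C)cc1` carries a propylsulfamoyl group on its anilino ring. In a functional assay on Huh-7 cells (Homo sapiens) for antiproliferative activity, read by CCK-8 assay, with a stated time of 72 h (on this read-out lower numbers stand for stronger inhibition of growth and higher numbers for weaker inhibition of growth), compound 1 gives 278 nM, the lowest of the two numbers measured here. Compound 3 `CCCNC(=O)c1ccc2c(ccn2-c2ncc3c(n2)N(c2ccn(C)n2)C(CC)C(=O)N3C)c1`, which shares the core but differs in several places, gives in this assay a value of 7280 nM, a gap that lies beyond the usual scatter. Compound 2 `CCC1C(=O)N(C)c2cnc(Nc3ccc(S(=O)(=O)NCCO)cc3)nc2N1c1ccn(C)n1`, also different in several places, is reported in this assay as "not active" (no number reported), without a number.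

Compound 4 `CC[C@@H]1C(=O)N(C)c2cnc(Nc3ccc(S(=O)(=O)Nc4ccccc4)cc3)nc2N1C1CCCC1` differs from compound 1 in one place only: phenyl in place of propyl on a sulfonamide nitrogen. Among the compounds with values here, no measured pair shows the effect of this exchange, so the expectation rests on compound 1 alone. The step from compound 1 to compound 4 is estimated as a 1.4-fold higher number from compound 1 to compound 4 (0.16 log units; within the scatter), a change that might stay within the scatter or drift slightly toward weaker inhibition. Compound 4 is therefore expected to give in this assay about 400 nM, within a range from 120 nM to 1300 nM.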

Compound 4, concentration for 50% growth inhibition: 2790 nM
Estimate against measurement, compound 4: 7.0-fold (0.84 log units) below, and the stated range ends below it.
By their numbers in this assay, from the lowest: compound 1; then compound 4; then compound 3.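

The sulfonamide nitrogen is not a neutral place for change: in this assay, phenyl in place of propyl gives a 10-fold higher number from compound 1 to compound 4 (1.00 log units; beyond the scatter) on the same core, a step beyond the usual scatter. Within the data shown here, this is the first exchange here made in one place only, so this loss of growth inhibition can be tied to that single exchange, which the earlier comparisons, all differing in several places, could not do. The data shown offer no measurement that explains the step.

On these data alone, it remains open whether the loss comes from the aromatic ring itself or simply from a larger group on this nitrogen. A cyclohexyl there would help separate these two readings, while a benzyl or a longer chain would show how far the position accepts added carbon.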